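Chloro for Methyl on the Core of Compound 2

The source may report more compounds than this note shows. Statements on the series, on what has been measured and on what is new or still open speak of the compounds shown alone.

Measured compounds:
compound 1, `CN1C(=O)/C(=C/C(=O)OC(C)(C)C)c2ccccc21`, in a toxicity assay on L02 cells (Homo sapiens) for inhibition, read by CCK-8 assay, with a stated time of 72 h, tested at 20 uM; on this read-out lower numbers stand for less inhibition of growth and higher numbers for more inhibition of growth at the one concentration tested: 61.4%
compound 2, `Cc1ccc2c(c1)/C(=C\C(=O)OC(C)(C)C)C(=O)N2`, in this assay: 63.9%

Of the compounds shown here, two have been measured so far. In this assay compound 1 gives 61.4%, and compound 2 gives 63.9%, the higher of the two numbers, though the gap between them lies within the scatter of repeated measurements, so the two cannot be ordered.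

Compound 3, `CC(C)(C)OC(=O)/C=C1/C(=O)Nc2ccc(Cl)cc21`, has not yet been measured. It differs from compound 2 in one place: chloro in place of methyl on an aromatic carbon. Within the data shown here, no step between two measured compounds shows what such an exchange does here, so the expectation rests on the two values alone. Compound 3 is expected to stay close to compound 2, with no step beyond the scatter; the estimated step is a number 0.9 percentage points lower from compound 2 to compound 3 (within the scatter). The value estimated for compound 3 is 63%, with a range from 48% to 78%.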

Compound 3, percent growth inhibition at one concentration: 63.3%
For compound 3 the middle estimate is 0.3 percentage points below the measured one, and the stated range covers the measured number.
By their numbers in this assay, from the lowest: compounds 1, 3 and 2 (each within the scatter of the next).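

Among these compounds, the step is the first measured exchange at this place on the core, the aromatic carbon meta to a fused ring and para to a fused ring. In this assay, chloro in place of methyl gives a number 0.6 percentage points lower from compound 2 to compound 3 (within the scatter), so on this read-out the two groups cannot be told apart, and a single heavy atom exchanged here, carbon for chlorine, leaves no measurable mark. No measurement shown here offers an explanation for this result.

The compounds shown leave open whether this insensitivity holds only for a pair such as methyl and chloro, or whether a larger or charged group on the same aromatic carbon, such as an amine or a carboxylic acid, would move the number beyond the scatter. They also leave open whether compound 2 and compound 3 would still read alike at concentrations other than the single one tested.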